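This account rests on a few compounds, and the source may have more. Where it says the series, first, only, none or still open, it means among the compounds named here.

Measured compounds:

compound 1 `Cc1nc(COc2ccc(/C=C3\SC(=O)NC3=O)cc2)cs1`: 19.2%

compound 2 `O=C1NC(=O)/C(=C/c2ccc(OCCSc3nnc(-c4ccccc4)[nH]3)cc2)S1`: 19.2%

In a functional assay on the whole organism (strain Wistar) with Rattus norvegicus as the target, with a stated time of 15 days, at a dose of 10 mg/kg by the oral route (on this read-out lower numbers stand for a weaker effect and higher numbers for a stronger effect at the one dose given), compound 1 gives 19.2%. In this assay compound 2 gives 19.2%. Compound 2 therefore stands level with compound 1: the two values show no difference at the digits reported, and the pair lies within the scatter of repeated measurements, so nothing can be said of an order between them. Within the data shown here, no step between measured compounds is available, as no two of them differ in only one place.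

Compound 3 `O=C1NC(=O)/C(=C/c2ccc(OCCSc3nnc(-c4ccc([N+](=O)[O-])cc4)[nH]3)cc2)S1` remains to be measured in this assay. It departs from compound 2 by one change, (nitro in place of hydrogen on an aromatic carbon), the same difference read one bond further out being phenyl to 4-nitrophenyl, on the aromatic carbon para to a large group. Among the measured compounds shown here, no measured pair shows what such a change does on this read-out. The expected step of a number 1.8 percentage points higher from compound 2 to compound 3 (within the scatter) is small and of no settled direction, not beyond the scatter. For compound 3 the estimated reading in this assay is 21%, with a range from 8% to 40%.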

Compound 3, a percentage reported as activity, at one dose (the size of the read-out at that dose, not a potency): 15.3%
Estimate against measurement, compound 3: 5.7 percentage points above, within the range that was stated.
By their numbers in this assay, from the lowest: compounds 3, 1 and 2 (each within the scatter of the next).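

In this assay, among these compounds, nitro in place of hydrogen on an aromatic carbon, para to a large group, gives the first step that can be read at this position: a number 3.9 percentage points lower from compound 2 to compound 3 (within the scatter). The position thus carries the 3 heavy atoms of the nitro group, in the change from phenyl to 4-nitrophenyl, with a step that stays within the scatter, so this single pair shows no settled direction and supports no trend. No measurement at hand gives any reason for this outcome.

Going by these compounds, whether any group on this aromatic carbon can move the read-out beyond the scatter remains open, and an amine, a carboxylic acid or a methoxy group in the place of the nitro group would each put that to a further test. The part played by the chain joining the triazole-bearing side to the core is also open: compound 1 and compound 2 differ in more than one place and cannot be compared as a step, and a longer chain has no counterpart among these compounds.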